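A few compounds are considered here, and "the series" means these few. Any claim that something is new, unique, unknown or untested is made for them only; others in the source may bear on it.

For the measured compounds named here, compound 1 `CC1(C)C=C(n2ccccc2=O)c2ccccc2O1` gives 5.43 in a functional assay (aorta) with Rattus norvegicus as the target (a higher number here means a more potent compound, by a factor of ten per unit of this negative logarithm, a lower number a less potent compound), the lowest of the three numbers known here. Going by the values given here, compound 2 `COc1ccc(C(=O)c2ccc3c(c2)C(n2ccccc2=O)=CC(C)(C)O3)cc1` reaches 6.15 and compound 3 `CC1(C)C=C(n2ccccc2=O)c2cc(C(=O)c3ccc([N+](=O)[O-])cc3)ccc2O1` reaches 6.2, both beyond the scatter above compound 1; no step is computed for either pair, so only the values themselves speak. The step of a number 0.05 log units higher from compound 2 to compound 3 (within the scatter) shows that the aryl ring of the carbonyl group tolerates different substituents without changing the read-out. Compound 4 `Cc1ccccc1C(=O)c1ccc2c(c1)C(n1ccccc1=O)=CC(C)(C)O2` follows the change ((2-methylphenyl)carbonyl in place of hydrogen on an aromatic carbon). Because compound 2 gives 6.15 and compound 3 gives 6.2 with such a group, both far above compound 1, an upward step of similar size is expected here, namely a number 0.72 log units higher from compound 1 to compound 4 (beyond the scatter). Compound 4 is therefore estimated at 6.15, within a range from 5.7 to 6.6.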

Compound 4, logarithm of the reciprocal of the active concentration, log(1/C): 6.83
Estimate against measurement, compound 4: 0.68 log units below, and the stated range ends below it.
By their numbers in this assay, from the lowest: compound 1; then compounds 2 and 3 (each within the scatter of the next); then compound 4.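

The change brings a number 1.40 log units higher from compound 1 to compound 4 (beyond the scatter) and so shows that this aromatic carbon can yield more gain than compound 2 and compound 3 suggested. The aryl group on the carbonyl also turns out to matter: 2-methylphenyl gives a number 0.63 log units higher from compound 3 to compound 4 (beyond the scatter) and a number 0.68 log units higher from compound 2 to compound 4 (beyond the scatter) even though 4-nitrophenyl and 4-methoxyphenyl lie within the scatter of each other. No measurement available here explains this difference.

The compounds shown leave open how a plain phenyl, a 4-methylphenyl or a 2-chlorophenyl on the same carbonyl would compare. They also leave open whether the carbonyl itself is needed.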